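The compounds below may be only part of what the source reports. "The series", "measured", "known", "first", "only" and "open" are said of these compounds alone.

Working notes on the series.

Compound 1 `COc1cc2c(Oc3ccc(NC(=O)c4nn(-c5ccccc5Br)c(=O)c5ccccc45)cc3F)ccnc2cc1OCCCN1CCCC1` carries a 2-bromophenyl on the aromatic nitrogen; in a functional assay on MDA-MB-231 cells (Homo sapiens) for cytotoxicity, read by MTT assay, with a stated time of 72 h (on this read-out higher numbers stand for weaker inhibition and lower numbers for stronger inhibition), compound 1 gives 1020 nM. Compound 2 `COc1cc2c(Oc3ccc(NC(=O)c4nn(-c5ccc([N+](=O)[O-])cc5)c(=O)c5ccccc45)cc3F)ccnc2cc1OCCCN1CCCC1` differs from compound 1 only in the change 4-nitrophenyl in place of 2-bromophenyl on an aromatic nitrogen and in this assay compound 2 gives 2980 nM, a step of a 2.9-fold higher number from compound 1 to compound 2 (0.47 log units; beyond the scatter). Compound 3 `COc1cc2c(Oc3ccc(NC(=O)c4nn(-c5ccccc5Br)c(=O)c5ccccc45)cc3F)ccnc2cc1OCCCN1CCN(C)CC1` keeps the 2-bromophenyl but differs from compound 1 in its core, by the change (4-methylpiperazin-1-yl in place of pyrrolidin-1-yl on a saturated chain carbon, three bonds along the chain from an oxygen on an aromatic ring); in this assay compound 3 gives 1680 nM, a step of a 1.6-fold higher number from compound 1 to compound 3 (0.22 log units; within the scatter).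

Compound 4 `COc1cc2c(Oc3ccc(NC(=O)c4nn(-c5ccc([N+](=O)[O-])cc5)c(=O)c5ccccc45)cc3F)ccnc2cc1OCCCN1CCN(C)CC1` is compound 3 with the change (4-nitrophenyl in place of 2-bromophenyl on an aromatic nitrogen). The place description matches that of the change from compound 1 to compound 2 word for word, so the same change is made on the core of compound 3. For the measured compounds named here, the expectation is that the step repeats, because in the single earlier instance the step from compound 1 to compound 2 was a 2.9-fold higher number from compound 1 to compound 2 (0.47 log units; beyond the scatter), and the core change from compound 1 to compound 3 was a 1.6-fold higher number from compound 1 to compound 3 (0.22 log units; within the scatter), small. Compound 4 is therefore expected to show a step of a 2.9-fold higher number from compound 3 to compound 4 (0.46 log units; beyond the scatter) in this assay. Compound 4 is estimated at 4900 nM, between 2500 nM and 9500 nM.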

Compound 4, half-maximal inhibitory concentration: 3490 nM
Compound 4: the middle estimate sits 1.4-fold (0.15 log units) above what was measured; the range from low to high includes it.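

In this assay, 4-nitrophenyl in place of 2-bromophenyl on the core carrying the 4-methylpiperazin-1-yl gives a 2.1-fold higher number from compound 3 to compound 4 (0.32 log units; beyond the scatter), and this step agrees with the earlier one on the core carrying the pyrrolidin-1-yl: the same change on two cores in this assay, a 2.9-fold higher number (0.47 log units; beyond the scatter) from compound 1 to compound 2 and a 2.1-fold higher number (0.32 log units; beyond the scatter) from compound 3 to compound 4, 1.4-fold (0.15 log units) apart, within the scatter of two such steps. The exchange of pyrrolidin-1-yl for 4-methylpiperazin-1-yl, read with the 4-nitrophenyl in place, gives a 1.2-fold higher number from compound 2 to compound 4 (0.07 log units; within the scatter), which likewise agrees with its counterpart carrying the 2-bromophenyl: the same change on two cores in this assay, a 1.6-fold higher number (0.22 log units; within the scatter) from compound 1 to compound 3 and a 1.2-fold higher number (0.07 log units; within the scatter) from compound 2 to compound 4, 1.4-fold (0.15 log units) apart, within the scatter of two such steps. Each change therefore carries over from one core to the other in these four compounds, but this rests on a single pair of steps for each change and does not show that either step would hold for other groups or other cores.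

From the compounds shown here alone, it remains open whether the step keeps its size with another group on the aromatic nitrogen, such as an unsubstituted phenyl or a 4-methoxyphenyl. Going by these compounds, it is equally open whether it holds with a morpholine or a dimethylamino group in place of the pyrrolidin-1-yl.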